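This account rests on a few compounds, and the source may have more. Where it says the series, first, only, none or still open, it means among the compounds named here.

Working notes on the series.

Going by the values given here, compound 2 `Cc1ccc(C2CCN(CC(=O)Nc3cccc(C)c3)CC2)nc1` gives the lowest of the two numbers so far: in an assay on HEK293 cells for displacement of a labelled ligand from D(4) dopamine receptor (Homo sapiens), read by scintillation counting, with a stated time of 90 min (a higher number here means a weaker inhibitor, a lower number a stronger inhibitor), compound 2 gives 6.87 nM. Among the compounds with values here, the only other measured member, compound 1 `Cc1cccc(NC(=O)CCN2CCN(c3ccccn3)CC2)c1`, gives 32.2 nM in this assay, and the gap between the two lies beyond the usual scatter, so compound 2 is the stronger inhibitor of the pair. Within the data shown here, compound 1 and compound 2 differ in several places at once, so no single step between them can be read off.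

Compound 3 `Cc1cccc(NC(=O)CN2CCC(c3ccccc3)CC2)c1` is the next member and is still to be measured in this assay. Relative to compound 2 the change is phenyl in place of 5-methylpyridin-2-yl on a saturated ring carbon. The rest of the molecule is kept. Among the measured compounds shown here, no measured step covers this change, so the expected step from compound 2 to compound 3 is a 1.6-fold higher number from compound 2 to compound 3 (0.20 log units; within the scatter), estimated to lie within or only slightly beyond the scatter, if anything toward a weaker inhibitor. For compound 3 the estimate in this assay is 11 nM, with a range from 3 nM to 40 nM.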

Compound 3, inhibition constant: 1.4 nM
Compound 3: the middle estimate sits 7.9-fold (0.90 log units) above what was measured, outside the stated range (below it).
By their numbers in this assay, from the lowest: compound 3; then compound 2; then compound 1.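

Going by these compounds alone, on a saturated ring carbon, three ring bonds from the ring nitrogen, phenyl in place of 5-methylpyridin-2-yl gives a 4.9-fold lower number from compound 2 to compound 3 (0.69 log units; beyond the scatter) in this assay, the only step so far that can be read at a single place. The step lies beyond the scatter and runs toward the stronger inhibitor, which shows that this position responds to the identity of its aromatic ring, something the multi-place comparison of compound 1 and compound 2 could not show; it also shows that a low number at this position does not depend on the hydrogen-bond acceptor counted in the 5-methylpyridin-2-yl group, since phenyl has none. Nothing available accounts for the size or direction of this step.

The change removes the ring nitrogen and the methyl together, and their separate shares remain unresolved; pyridin-2-yl without the methyl, or phenyl bearing a methyl, would separate them. Also open, going by these compounds, is how the number responds to other groups on the phenyl ring, such as a fluorine or a methoxy.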